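Working notes: nitro in place of chloro

The compounds below may be only part of what the source reports. "The series", "measured", "known", "first", "only" and "open" are said of these compounds alone.

Values so far in a functional assay on HaCaT cells (Homo sapiens) for cytotoxicity, with a stated time of 48 h (a higher number here means a weaker inhibitor, a lower number a stronger inhibitor), are as follows
- compound 1 `COc1cc(OC)c(C(=O)/C=C/c2ccccc2OC)c(OC)c1` gives 8700 nM
- compound 2 `COc1cccc(/C=C/C(=O)c2c(OC)cc(OC)cc2OC)c1` gives 5300 nM
- compound 3 `COc1cc(OC)c(C(=O)/C=C/c2ccc(Cl)cc2)c(OC)c1` gives 7600 nM

These compounds share one core and carry 2-methoxyphenyl, 3-methoxyphenyl or 4-chlorophenyl on the same double-bonded chain carbon. Compound 3 cannot be separated from the other two, as a 1.1-fold lower number from compound 1 to compound 3 (0.06 log units; within the scatter) and a 1.4-fold higher number from compound 2 to compound 3 (0.16 log units; within the scatter) both stay within the scatter. The remaining step, a 1.6-fold lower number from compound 1 to compound 2 (0.22 log units; within the scatter), is also within the scatter.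

Compound 4 `COc1cc(OC)c(C(=O)/C=C/c2ccc([N+](=O)[O-])cc2)c(OC)c1` keeps the core of compound 3 and carries nitro in place of chloro on an aromatic carbon, para to a large group (nitro in place of chloro on an aromatic carbon). For the measured compounds named here, no measured step involves nitro, so the evidence is indirect. Across these three compounds, none goes against a flat picture, and the largest change seen is still the step of a 1.6-fold lower number from compound 1 to compound 2 (0.22 log units; within the scatter) within the scatter. No step beyond the scatter is therefore expected in this assay, though the range must stay wide for an untested group. The expected step is a 1.3-fold lower number from compound 3 to compound 4 (0.10 log units; within the scatter) and carries no firm direction. For compound 4 the estimated value is 6000 nM with an expected range from 2500 nM to 13000 nM as the upper end.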

Compound 4, half-maximal inhibitory concentration: 2800 nM
Beside the measured number, compound 4's estimate is 2.1-fold (0.33 log units) above it; low and high end bracket the measured number.
By their numbers in this assay, from the lowest: compounds 4, 2, 3 and 1 (each within the scatter of the next, the first and the last beyond it).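

In this assay the exchange of chloro for nitro on an aromatic carbon, para to a large group, gives a 2.7-fold lower number from compound 3 to compound 4 (0.43 log units; beyond the scatter) and is the only step shown that passes beyond the scatter, whereas every step among compound 1, compound 2 and compound 3 stays within it. The aryl position of this series is therefore not flat for every replacement, although the step is modest, rests on a single pair, and leaves compound 4 within the scatter of compound 2, so that compound 4 does not stand apart from all of the series. Nothing available bears on why this exchange moves the number, and the result stays a plain observation on one pair of compounds.

On these data alone, it remains open whether an amine, a carboxylic acid or a trifluoromethyl group on the same aromatic carbon would follow nitro or stay with chloro, which would show whether the step is particular to nitro. Also open, as far as these compounds go, is whether nitro on another aromatic carbon of that ring, or on a different core, would give a step of similar size.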